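The compounds below may be only part of what the source reports. "The series", "measured", "known", "first", "only" and "open" are said of these compounds alone.

Notes on the series. In a functional assay on the whole organism for antagonist activity, with Mus musculus as the target (on this read-out lower numbers stand for an effect already at smaller amounts and higher numbers for an effect only at larger amounts of compound), compound 2 `CCOC(=O)N(C)C(C)C#CCN1CCCC1` gives > 100 mg/kg, which is a limit and not a number, so it has no measured position. Compound 1 `CC(=O)N(C)C(C)C#CCn1ccnc1`, which carries 1H-imidazol-1-yl, gives > 100 mg/kg, also a limit. Within the data shown here, the series so far therefore offers only (the limit of > 100 mg/kg in this assay, at which 2 of the 2 values shown sit). Compound 3 `CCOC(=O)N(C)C(C)C#CCn1ccnc1` differs from compound 2 by one change: 1H-imidazol-1-yl in place of pyrrolidin-1-yl on a saturated chain carbon bound to a triple-bonded carbon. In this assay no change beyond the scatter is expected, and the estimated step is a number no higher from compound 2 to compound 3 (the limit leaves the size open). For compound 3 the estimated value is 100 mg/kg, with an expected range from 30 mg/kg to 300 mg/kg.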

Compound 3, dose for half-maximal effect: 66 mg/kg
For compound 3 the middle estimate is 1.5-fold (0.18 log units) above the measured one; measured number inside the range.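

Compound 3 is the only compound shown in this assay with a number rather than a limit. 1H-imidazol-1-yl in place of pyrrolidin-1-yl on a saturated chain carbon bound to a triple-bonded carbon gives an at least 1.5-fold lower number from compound 2 to compound 3 (0.18 log units; that floor lies within the scatter), and ethoxy in place of methyl on a carbonyl carbon gives an at least 1.5-fold lower number from compound 1 to compound 3 (0.18 log units; that floor lies within the scatter). Both steps start from a limit, so each is only a floor: the limit of > 100 mg/kg in this assay, at which 2 of the 3 values shown sit.

On these data alone, how far either step reaches beyond its floor stays open. Also open, as far as these compounds go, is how a primary amine or a morpholin-4-yl group on that saturated chain carbon would read.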